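The compounds below may be only part of what the source reports. "The series", "measured", "known", "first", "only" and "open" are said of these compounds alone.

Measured compounds:
Compound 1, `COc1cc2c(cc1OC)C(CC(=O)N(C)C)CC2`, gives 25% in a functional assay on the whole organism (strain Wistar) for inhibition, with Rattus norvegicus as the target, read by paw edema, with stated times of 60 min and 1 h, at a dose of 100 mg/kg by the oral route; a higher number here means more inhibition at the dose given (going by the name of the read-out), a lower number less inhibition.
Compound 2, `CCCNC(=O)CC1CCc2cc(OC)c(OC)cc21`, gives 18.8%.

On these two numbers compound 2 sits alongside compound 1: the step of a number 6.2 percentage points lower from compound 1 to compound 2 (within the scatter) lies within the scatter, so neither stands apart. Compound 3, `COc1cc2c(cc1OC)C(CC(=O)NC(C)(C)C)CC2`, differs from compound 2 by tert-butyl in place of propyl on an amide-type nitrogen. For the measured compounds named here, the one measured step that bears on this, a number 6.2 percentage points lower from compound 1 to compound 2 (within the scatter), also swapped the group on the amide nitrogen and stayed within the scatter, so no change beyond the scatter is expected, a number 1.2 percentage points higher from compound 2 to compound 3 (within the scatter). Compound 3 is therefore estimated at 20%, likely between 8% and 32%.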

Compound 3, a percentage reported as inhibition, in the whole organism at one dose (the size of the read-out at that dose, not a potency): 31.3%
For compound 3 the middle estimate is 11.3 percentage points below the measured one; measured number inside the range.
By their numbers in this assay, from the lowest: compounds 2, 1 and 3 (each within the scatter of the next, the first and the last beyond it).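

In this assay, for the compounds shown here, the group on the amide-type nitrogen can shift the result: tert-butyl in place of propyl gives a number 12.5 percentage points higher from compound 2 to compound 3 (beyond the scatter) and is the first step here to pass the scatter. Against dimethylamino, however, (tert-butyl)amino gives a number 6.3 percentage points higher from compound 1 to compound 3 (within the scatter) so compound 1 and compound 3 cannot be ranked. No measurement here explains the tert-butyl step.

From the compounds shown here alone, whether the step extends to other groups on this nitrogen stays open, such as isopropyl, benzyl or a longer chain like hexyl. Going by these compounds, a carboxylic acid in place of the amide also remains untested here.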